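Replacing 3,5-dichloro-2-hydroxyphenyl with 2-phenylethenyl

This account rests on a few compounds, and the source may have more. Where it says the series, first, only, none or still open, it means among the compounds named here.

In an ADME assay on NIH3T3 cells (Mus musculus) for cytotoxicity, read by MTT assay, with a stated time of 24 h (a higher number here means a weaker inhibitor, a lower number a stronger inhibitor), compound 1 `O=C(CSc1nnc(-c2ccncc2)o1)N/N=C/c1ccc([N+](=O)[O-])cc1` gives 195000 nM and compound 2 `O=C(CSc1nnc(-c2ccncc2)o1)N/N=C/c1cc(Cl)cc(Cl)c1O` gives 171000 nM, so these two values lie within the scatter of each other. Compound 3 `O=C(CSc1nnc(-c2ccncc2)o1)N/N=C/C=C/c1ccccc1` has 2-phenylethenyl in place of 3,5-dichloro-2-hydroxyphenyl on a carbon with a double bond to nitrogen. For the measured compounds named here, only one measured step bears on this change, a 1.1-fold lower number from compound 1 to compound 2 (0.06 log units; within the scatter), and it swapped the group at the same place while staying within the scatter. The step expected in this assay is therefore a 1.0-fold lower number from compound 2 to compound 3 (0.00 log units; within the scatter), none beyond the scatter. Compound 3 is estimated at 170000 nM, with a range from 80000 nM to 320000 nM.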

Compound 3, half-maximal inhibitory concentration: 160000 nM
Compound 3: middle estimate off by 1.1-fold (0.03 log units), on the high side; the range from low to high includes it.
By their numbers in this assay, from the lowest: compounds 3, 2 and 1 (each within the scatter of the next).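

At this place, on a carbon with a double bond to nitrogen, this assay now also covers a group with a double bond outside aromatic rings and with 0 hydrogen-bond donors: the result is a 1.1-fold lower number from compound 2 to compound 3 (0.03 log units; within the scatter) and also a 1.2-fold lower number from compound 1 to compound 3 (0.09 log units; within the scatter) when set against 4-nitrophenyl. All three groups therefore give values within the scatter of one another, whereas the two earlier groups both had their ring bonded directly to that carbon. Still open, as far as these compounds go, is whether an amine, a carboxylic acid or a longer chain at this place would give a step beyond the scatter. No measurement here explains why these values lie so close.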